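Swapping a Furan for Cyclopentyl on a Piperidine Amine

The compounds below may be only part of what the source reports. "The series", "measured", "known", "first", "only" and "open" are said of these compounds alone.

Compound 2 `COc1cccc(-n2cc3nc(-c4cccnc4C)n(C[C@H]4CCCN(Cc5ccco5)C4)c(=O)c3n2)c1` gives 2.7 nM in an assay on HEK293 cells for displacement of a labelled ligand from growth hormone secretagogue receptor type 1 (Homo sapiens), with a stated time of 60 min (on this read-out higher numbers stand for weaker inhibition and lower numbers for stronger inhibition), the lower of the two numbers recorded so far; compound 1 `Cc1ccccc1-c1nc2cn(-c3cccc(C#N)c3)nc2c(=O)n1CC1CCCN(C(C)C)C1` gives 32 nM in this assay, and that gap lies beyond the usual scatter. Compound 3 `COc1cccc(-n2cc3nc(-c4cccnc4C)n(C[C@H]4CCCN(CC5CCCC5)C4)c(=O)c3n2)c1` has not yet been measured in this assay. It differs from compound 2 in a single place: cyclopentyl in place of furan-2-yl on a saturated chain carbon bound to an amine nitrogen in a ring. Within the data shown here, no measured pair in this set isolates that change, so there is no direct precedent for its size. The expectation therefore rests on compound 2 alone, whose value of 2.7 nM anchors the estimate. The step is expected to be small, a 1.5-fold higher number from compound 2 to compound 3 (0.17 log units; within the scatter), with no clear direction beyond the scatter. Compound 3 is accordingly estimated at 4 nM in this assay, within a range from 1.5 nM to 12 nM.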

Compound 3, half-maximal inhibitory concentration: 12 nM
The estimate for compound 3 lay 3.0-fold (0.48 log units) below the measured number, and the stated range covers the measured number.
By their numbers in this assay, from the lowest: compound 2; then compound 3; then compound 1.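

Placing cyclopentyl in place of furan-2-yl on a saturated chain carbon bound to an amine nitrogen in a ring gives a 4.4-fold higher number from compound 2 to compound 3 (0.65 log units; beyond the scatter) in this assay. Among these compounds, this is the first pair to isolate a change at this position, and it shows that the position is not indifferent to the swap, even though the heavy-atom count stays the same while the aromatic ring and its hydrogen-bond acceptor leave. Nothing measured here explains the step. The compounds shown leave open whether the oxygen or the aromatic ring matters more, since the two leave together in this change. A tetrahydrofuran-2-yl group, which keeps the oxygen in a non-aromatic ring, and a thiophen-2-yl group, which keeps an aromatic ring without oxygen, would pull the two apart.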